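This account rests on a few compounds, and the source may have more. Where it says the series, first, only, none or still open, it means among the compounds named here.

Measured compounds:
- compound 1, `COc1ccccc1Nc1nnc(Nc2nc(-c3ccc([N+](=O)[O-])cc3)cs2)s1`: 300 mg/kg
- compound 2, `COc1ccc(Nc2nnc(Nc3nc(-c4ccc([N+](=O)[O-])cc4)cs3)s2)cc1`: 100 mg/kg
- compound 3, `COc1ccccc1Nc1nnc(Nc2nc(-c3ccccc3)cs2)s1`: 300 mg/kg

Compound 4, `COc1ccc(Nc2nnc(Nc3nc(-c4ccccc4)cs3)s2)cc1`, is not yet measured in a functional assay on the whole organism (strain albino) with Mus musculus as the target, with a stated time of 4 h; on this read-out higher numbers stand for an effect only at larger amounts of compound and lower numbers for an effect already at smaller amounts.

Compound 1 and compound 2 differ by 4-methoxyphenyl in place of 2-methoxyphenyl on a nitrogen on an aromatic ring; in this assay that change gives a 3.0-fold lower number from compound 1 to compound 2 (0.48 log units; beyond the scatter). Compound 1 and compound 3 differ by hydrogen in place of nitro on an aromatic carbon; this gives no change at the digits printed from compound 1 to compound 3 (within the scatter), so compound 3 stands level with compound 1.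

Compound 4 differs from compound 3 by 4-methoxyphenyl in place of 2-methoxyphenyl on a nitrogen on an aromatic ring. The place line reads the same as for the change from compound 1 to compound 2, so this is the same change made on the core of compound 3 instead of the core of compound 1. The expectation for compound 4 rests on that one earlier step, a 3.0-fold lower number from compound 1 to compound 2 (0.48 log units; beyond the scatter), and on the value of compound 3, 300 mg/kg. With a single precedent the expected step is a 3.0-fold lower number from compound 3 to compound 4 (0.48 log units; beyond the scatter), and compound 4 is estimated at 100 mg/kg, between 50 mg/kg and 300 mg/kg.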

Compound 4, minimum effective dose: 300 mg/kg
Beside the measured number, compound 4's estimate is 3.0-fold (0.48 log units) below it; the range from low to high includes it.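

In this assay, 4-methoxyphenyl in place of 2-methoxyphenyl on a nitrogen on an aromatic ring gives no change at the digits printed from compound 3 to compound 4 (within the scatter), so the step seen on the core of compound 1 does not carry over to the core of compound 3: the same change on two cores in this assay, a 3.0-fold lower number (0.48 log units; beyond the scatter) from compound 1 to compound 2 and no change at the digits printed (within the scatter) from compound 3 to compound 4, 3.0-fold (0.48 log units) apart, beyond the scatter of two such steps. Hydrogen in place of nitro on an aromatic carbon gives a 3.0-fold higher number from compound 2 to compound 4 (0.48 log units; beyond the scatter), so that change also reads differently on the two cores: the same change on two cores in this assay, no change at the digits printed (within the scatter) from compound 1 to compound 3 and a 3.0-fold higher number (0.48 log units; beyond the scatter) from compound 2 to compound 4, 3.0-fold (0.48 log units) apart, beyond the scatter of two such steps. Both gaps come from the same four compounds and amount to one observation: the two changes do not act independently here, but the data do not show why, or whether this holds on any other core.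

Open, from the compounds shown here alone, is whether the lower number of compound 2 depends on nitro itself or would also appear with a nitrile, a chlorine or a carboxylic acid on that aromatic carbon. Also open, going by these compounds, is how an amine or a longer chain in place of methoxy would read on either core.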